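A few compounds are considered here, and "the series" means these few. Any claim that something is new, unique, unknown or untested is made for them only; others in the source may bear on it.

Measured compounds in this series:

Compound 1 `O=C1[C@H]2[C@H](ON(c3ccccc3)[C@@H]2c2coc3ccc(F)cc3c2=O)C(=O)N1c1ccccc1`. In a functional assay on Caco-2 cells (Homo sapiens) for inhibition, read by sulforhodamine B assay, with a stated time of 48 h (a lower number here means a stronger inhibitor, a higher number a weaker inhibitor), compound 1 gives > 60000 nM, which is a limit of the assay.
Compound 2 `Cc1ccc2occ([C@@H]3[C@H]4C(=O)N(c5ccccc5)C(=O)[C@H]4ON3c3ccccc3)c(=O)c2c1`. In this assay compound 2 gives > 60000 nM, also a limit of the assay.
Compound 3 `COC(=O)[C@@]1(C)C[C@@H](c2coc3ccc(F)cc3c2=O)N(c2ccccc2)O1`. In this assay, among the compounds with values here, compound 3 gives 29500 nM, the only number among the three values.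

The step that the two limits leave unreadable from compound 1 to compound 2 cannot be sized because of the limit of > 60000 nM in this assay, at which 2 of the 3 values shown sit. The change there is methyl in place of fluoro on an aromatic carbon. Compound 3 shares no counted difference with compound 1; the difference between the two cores is not broken down here.

Compound 4 `COC(=O)[C@@]1(C)C[C@@H](c2coc3ccc(C)cc3c2=O)N(c2ccccc2)O1` is not yet measured. It differs from compound 3 by methyl in place of fluoro on an aromatic carbon, the same change as from compound 1 to compound 2. The earlier step gives no readable size, so the expected step of a 1.0-fold higher number from compound 3 to compound 4 (0.01 log units; within the scatter) rests only on compound 3 with its 29500 nM, taken as unchanged. Compound 4 is therefore estimated at 30000 nM, between 8000 nM and 60000 nM.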

Compound 4, half-maximal inhibitory concentration: 19700 nM
Compound 4: middle estimate off by 1.5-fold (0.18 log units), on the high side; the range from low to high includes it.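

In this assay, methyl in place of fluoro on an aromatic carbon gives a 1.5-fold lower number from compound 3 to compound 4 (0.18 log units; within the scatter), so on the core of compound 3 this change has no size that can be told from the scatter. Within the data shown here, on the core of compound 1 the same change has no readable size, and the two cores cannot be compared for it, because both values there are limits: the limit of > 60000 nM in this assay, at which 2 of the 4 values shown sit. Carrying the change from one core to the other is therefore neither supported nor contradicted, since only one core gives a readable step.

Only fluoro and methyl are shown on this aromatic carbon. Going by these compounds, whether an amine or a carboxylic acid there would give a step beyond the scatter on either core remains open.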